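The source may hold more compounds than are shown below. What is called first, only, known or untested is meant among the compounds shown, and "the series" means these compounds.

Working notes on the series. Compound 1 `CSc1ccc(C(=O)Nc2nn[nH]n2)nc1` is the reference point. In a functional assay on the whole organism for inhibition, with Rattus norvegicus as the target, at a dose of 10 mg/kg by the oral route (a higher number here means a stronger effect of the compound at the dose given, a lower number a weaker effect), compound 1 gives 29%. For the measured compounds named here, the only other measured member, compound 2 `COc1cc(C)nc(C(=O)Nc2nn[nH]n2)c1`, gives in this assay a value of 20%. Compound 1 stands first of the two numbers, but the gap to compound 2 falls within the scatter of repeated measurements, so the two cannot be told apart on this evidence.

The next compound, compound 3 `Cc1ccc(C(=O)Nc2nn[nH]n2)nc1`, differs from compound 1 in one place: methyl in place of methylsulfanyl on an aromatic carbon. Going by the values given here, no measured pair shows the effect of this change, so the expectation rests on compound 1 alone. Given that compound 1 gives 29%, the step from compound 1 to compound 3 is expected to be small, a number 7 percentage points lower from compound 1 to compound 3 (within the scatter), and not clearly beyond the scatter in either direction. Compound 3 is estimated at 22% in this assay, with a range from 5% to 40%.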

Compound 3, a percentage reported as inhibition, in the whole organism at one dose (the size of the read-out at that dose, not a potency): 42%
Beside the measured number, compound 3's estimate is 20 percentage points below it; measured number above the stated range.
By their numbers in this assay, from the lowest: compounds 2 and 1 (each within the scatter of the next); then compound 3.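

For the compounds shown here, compound 3 gives the first readable step: in this assay, methyl in place of methylsulfanyl on this aromatic carbon, two atoms from the ring nitrogen, gives a number 13 percentage points higher from compound 1 to compound 3 (beyond the scatter) at the dose given. The sulfur atom of compound 1 is therefore not needed at this place for the effect, and the smaller group gives the larger read-out on the core of compound 1. No measurement bears on why this change raises the read-out.

This single pair cannot separate a gain from methyl itself from a gain from losing methylsulfanyl. On these data alone, it remains open how a bare hydrogen, an ethyl group or a chlorine atom at this place would compare with methyl.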